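Cytotoxicity tolerance notes on compounds 1 to 4

This account rests on a few compounds, and the source may have more. Where it says the series, first, only, none or still open, it means among the compounds named here.

Compound 1, `CCCN1C(N)=NC(N)=NC12CCN(C(=O)C1CC1)CC2`: in an ADME assay on MDCK cells (Canis lupus familiaris) for cytotoxicity, read by microscopy, with a stated time of 6 days (a higher number here means that more compound is tolerated, a lower number that less compound is tolerated), compound 1 gives > 100000 nM, a limit of the assay rather than a number.
Compound 2, `COCCN1C(N)=NC(N)=NC12CCN(C(=O)C1CC1)CC2`: compound 2 gives > 100000 nM, again a limit.
Compound 3, `COCCN1C(N)=NC(N)=NC12CCN(C(=O)c1cccn1C)CC2`: compound 3 gives > 100000 nM, also a limit.

All three measured values rest at the same point, (the limit of > 100000 nM in this assay, at which 3 of the 3 values shown sit). The step that the two limits leave unreadable from compound 1 to compound 2 and the step that the two limits leave unreadable from compound 2 to compound 3 are therefore both unreadable; neither tells whether the change at the amine nitrogen in the ring or the change on the carbonyl carbon moved tolerance at all. Compound 3 thus stands at the limit, with nothing in the series above or below it to rank it against.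

Compound 4, `COCCN1C(N)=NC(N)=NC12CCN(C(=O)NC1CCC(C)CC1)CC2`, differs from compound 3 by (4-methylcyclohexyl)amino in place of 1-methyl-1H-pyrrol-2-yl on a carbonyl carbon. For the measured compounds named here, no measured step concerns a (4-methylcyclohexyl)amino group or an amine attached to the carbonyl carbon, so the only bearing evidence is that every change made so far, including one on the same carbonyl carbon, left the value at the limit. The expectation is that compound 4 behaves alike and that the step of a number no higher from compound 3 to compound 4 (the limit leaves the size open) is none beyond the scatter. Compound 4 is thus estimated at 100000 nM, within 40000 nM to 300000 nM, most likely reported again only as a limit.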

Compound 4, minimum cytotoxic concentration: > 100000 nM
Compound 4: no number, only a limit; the forecaster's own chance of this, stated with the estimate: 80%; the middle value sits exactly at the limit.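

Compound 4 gives > 100000 nM, again a limit and not a number. The steps to compound 4 from compound 2 and compound 3 therefore cannot be read, and the series stays at one point: the limit of > 100000 nM in this assay, at which 4 of the 4 values shown sit.

The compounds shown leave open at what concentration any of them becomes cytotoxic, and whether any change made moves tolerance at all.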